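This account rests on a few compounds, and the source may have more. Where it says the series, first, only, none or still open, it means among the compounds named here.

Compound 1 `Fc1cccc(NC(=S)N/N=C/c2ccc3ccccc3n2)c1` was tested in a functional assay on HT-29 cells (Homo sapiens) for antiproliferative activity, read by sulforhodamine B assay, with a stated time of 72 h (a lower number here means a stronger inhibitor, a higher number a weaker inhibitor), where compound 1 gives 74700 nM. Within the data shown here, the only other measured compound, compound 2 `Cc1csc2sc(/C=N/NC(N)=S)c(C)c12`, gives 57500 nM; the two numbers lie within the usual scatter of each other, so both stand as weak inhibitors with nothing to choose between them.

Compound 3 `Cc1cccc(NC(=S)N/N=C/c2ccc3ccccc3n2)c1` is not yet measured. It differs from compound 1 in one place: methyl in place of fluoro on an aromatic carbon. Among the measured compounds shown here, no measured pair shows what such a change does here, so the expected step of a 1.2-fold lower number from compound 1 to compound 3 (0.10 log units; within the scatter) is none beyond the scatter. Compound 3 is expected to give about 60000 nM, somewhere between 25000 nM and 150000 nM.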

Compound 3, half-maximal inhibitory concentration: > 100000 nM
Compound 3: a limit, no number; the forecaster's own chance of this, stated with the estimate: 15%; middle value at least 1.6-fold (0.22 log units) away from the limit.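

Compound 3 carries a limit of the assay and not a number: the limit of > 100000 nM in this assay, at which 1 of the 3 values shown sits. The change from 3-fluorophenyl to 3-methylphenyl gives an at least 1.3-fold higher number from compound 1 to compound 3 (0.12 log units; that floor lies within the scatter), so this step has only a floor, and that floor does not clear the scatter. Going by these compounds, this first pair sharing one core shows that methyl brings no gain over fluoro at this position, while the true size of the step stays unknown.

On these data alone, what an amine or a methoxy group on this carbon would do stays open, as does how compound 1 compares with a plain phenyl ring.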